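Bromo in Place of Chloro: An Antiproliferative Step Ahead

The source may report more compounds than this note shows. Statements on the series, on what has been measured and on what is new or still open speak of the compounds shown alone.

In a functional assay on DU-145 cells (Homo sapiens) for antiproliferative activity, read by MTT assay, with a stated time of 48 h (a higher number here means a weaker inhibitor, a lower number a stronger inhibitor), compound 1 `CN1C(=O)C(O)(Cc2nnn[nH]2)c2ccccc21` gives 36800 nM and compound 3 `CN1C(=O)C(O)(Cc2nnn[nH]2)c2cc(Cl)ccc21` gives 76000 nM as the higher of the two exact numbers. Compound 2 `CN1C(=O)C(O)(Cc2nnn[nH]2)c2cc(F)ccc21` gives > 100000 nM as a limit of the assay and not a number. Compound 4 `CN1C(=O)C(O)(Cc2nnn[nH]2)c2cc(Br)ccc21` differs from compound 3 by bromo in place of chloro on an aromatic carbon. The two steps away from hydrogen (an at least 2.7-fold higher number from compound 1 to compound 2 (0.43 log units; beyond the scatter) and a 2.1-fold higher number from compound 1 to compound 3 (0.31 log units; beyond the scatter)) are at least modest and beyond the scatter. The closest step, chloro in place of fluoro (an at least 1.3-fold lower number from compound 2 to compound 3 (0.11 log units; that floor lies within the scatter)), has a floor within the scatter. No step beyond the scatter is therefore expected, and the estimated change (a 1.1-fold higher number from compound 3 to compound 4 (0.02 log units; within the scatter)) stays small. In this assay compound 4 is estimated at 80000 nM (expected range 40000 nM to 140000 nM).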

Compound 4, half-maximal inhibitory concentration: > 100000 nM
Compound 4: no number, only a limit (the forecaster's own chance of this, stated with the estimate: 25%); middle value at least 1.2-fold (0.09 log units) away from the limit.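

The value of compound 4 is a limit of the assay and not a number. Bromo in place of hydrogen gives an at least 2.7-fold higher number from compound 1 to compound 4 (0.43 log units; beyond the scatter) and so makes all three halogens shown on this aromatic carbon weaker than hydrogen, with none of them going against that pattern. Bromo in place of chloro gives an at least 1.3-fold higher number from compound 3 to compound 4 (0.11 log units; that floor lies within the scatter) and thus sets no order between the two halogens. As far as these compounds go, whether an amine, a methoxy group or a carboxylic acid on this carbon would give a lower number than hydrogen stays open. The step between compound 2 and compound 4 also cannot be read, because both rest on the same limit: the limit of > 100000 nM in this assay, at which 2 of the 4 values shown sit.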